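The source may hold more compounds than are shown below. What is called first, only, known or untested is meant among the compounds shown, and "the series" means these compounds.

Four close relatives of one shared core are compared in a functional assay on A549 cells (Homo sapiens) for cytotoxicity, read by MTT assay, with a stated time of 48 h (a higher number here means a weaker inhibitor, a lower number a stronger inhibitor), a measure of how strongly each compound holds back the growth of a lung-cancer cell line. Compound 1 `C=CCn1c(-c2ccc(OC)cc2COCOC)cc2ccccc2c1=O` is the starting point. In this assay compound 1 reaches only the limit of the measurement, > 100000 nM, which is not a number but the edge of what the assay can read (the limit of > 100000 nM in this assay, at which 1 of the 3 values shown sits). Compound 2 `C=CCn1c(-c2cc(OC)c(OC)cc2COCOC)cc2ccccc2c1=O` carries one added group: methoxy in place of hydrogen on an aromatic carbon. In this assay compound 2 gives 88100 nM, so that an at least 1.1-fold lower number from compound 1 to compound 2 (0.05 log units; that floor lies within the scatter). Compound 3 `C=CCn1c(-c2ccc(OC)cc2C=O)cc2ccccc2c1=O` differs from compound 1 elsewhere: formyl in place of (methoxymethoxy)methyl on an aromatic carbon. In this assay compound 3 gives 88100 nM, and an at least 1.1-fold lower number from compound 1 to compound 3 (0.05 log units; that floor lies within the scatter). Compound 4 `C=CCn1c(-c2cc(OC)c(OC)cc2C=O)cc2ccccc2c1=O` has not yet been measured; it relates to compound 3 as compound 2 relates to compound 1: methoxy in place of hydrogen on an aromatic carbon. The surroundings differ only in that the entering group is para to a formyl group rather than para to a (methoxymethoxy)methyl group, so this is the same kind of change, not the same change. Resting on the earlier step, which began at a limit, the expected step is a 1.3-fold lower number from compound 3 to compound 4 (0.10 log units; within the scatter). Compound 4 is therefore estimated at 70000 nM, most likely between 30000 nM and 150000 nM.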

Compound 4, half-maximal inhibitory concentration: 76300 nM
For compound 4 the middle estimate is 1.1-fold (0.04 log units) below the measured one; the measured number falls inside the stated range.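

In this assay, methoxy in place of hydrogen on an aromatic carbon gives a 1.2-fold lower number from compound 3 to compound 4 (0.06 log units; within the scatter), and formyl in place of (methoxymethoxy)methyl gives a 1.2-fold lower number from compound 2 to compound 4 (0.06 log units; within the scatter), so neither change has a readable effect on this core. Each change can be set beside its earlier counterpart, and for methoxy the comparison shows no sign that the result depends on the core, though it cannot show that the two steps match: the same change on two cores in this assay, an at least 1.1-fold lower number (0.05 log units; that floor lies within the scatter) from compound 1 to compound 2 and a 1.2-fold lower number (0.06 log units; within the scatter) from compound 3 to compound 4; the limit leaves it open whether they differ. The formyl change reads the same way, with small steps that cannot be shown to be equal: the same change on two cores in this assay, an at least 1.1-fold lower number (0.05 log units; that floor lies within the scatter) from compound 1 to compound 3 and a 1.2-fold lower number (0.06 log units; within the scatter) from compound 2 to compound 4; the limit leaves it open whether they differ.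

Because all four compounds sit close to the top of the measurable range, these pairs say little about how a change that did shift the number would carry from one core to another: the limit of > 100000 nM in this assay, at which 1 of the 4 values shown sits. Going by these compounds, whether an amine or a carboxylic acid in place of the formyl, or a longer chain in place of the methoxy, would move the number beyond the scatter stays open.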